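The compounds below may be only part of what the source reports. "The series", "measured", "known", "first", "only" and "open" are said of these compounds alone.

Measured so far in a functional assay on SiHa cells (Homo sapiens) for cytotoxicity, read by MTT assay, with a stated time of 48 h; on this read-out lower numbers stand for stronger inhibition and higher numbers for weaker inhibition:
compound 1, `CCCCCCCCCCCCNC(=O)[C@@H](NC(=O)c1cc2ccccc2o1)[C@@H](C)O`, gives 12900 nM
compound 2, `CCCCCCCCCCCCNC(=O)[C@@H](NC(=O)c1nccc2ccccc12)[C@@H](C)O`, gives 56600 nM
compound 3, `CCCCCCCCCCCCCCNC(=O)[C@@H](NC(=O)c1cc2ccccc2o1)[C@@H](C)O`, gives 14200 nM

Compound 3 differs from compound 1 only in the chain, by ethyl in place of hydrogen on a saturated chain carbon, ten or more bonds along the chain from an amide-type nitrogen. The step of a 1.1-fold higher number from compound 1 to compound 3 (0.04 log units; within the scatter) shows the longer chain leaving the read-out essentially unchanged. Compound 2 differs from compound 1 at the acyl end, by isoquinolin-1-yl in place of 1-benzofuran-2-yl on a carbonyl carbon. Here the step of a 4.4-fold higher number from compound 1 to compound 2 (0.64 log units; beyond the scatter) is a clear loss of potency within this small set.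

Compound 4, `CCCCCCCCCCCCCCNC(=O)[C@@H](NC(=O)c1nccc2ccccc12)[C@@H](C)O`, has not yet been measured in this assay. It differs from compound 3 by isoquinolin-1-yl in place of 1-benzofuran-2-yl on a carbonyl carbon, the same change as from compound 1 to compound 2, at the same place. The step from compound 3 to compound 4 is expected to be about a 4.2-fold higher number from compound 3 to compound 4 (0.63 log units; beyond the scatter), because a 4.4-fold higher number from compound 1 to compound 2 (0.64 log units; beyond the scatter) gives the only measured size of this change and because a 1.1-fold higher number from compound 1 to compound 3 (0.04 log units; within the scatter) shows the chain difference between the two pairs to be of no consequence. On that basis compound 4 is estimated at 60000 nM, with the expected range running from 25000 nM to 150000 nM.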

Compound 4, half-maximal inhibitory concentration: 21600 nM
Compound 4: the middle estimate sits 2.8-fold (0.44 log units) above what was measured; the whole stated range lies above it.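

In this assay, isoquinolin-1-yl in place of 1-benzofuran-2-yl on a carbonyl carbon gives a 1.5-fold higher number from compound 3 to compound 4 (0.18 log units; within the scatter), and the size of this change does not carry over from the core of compound 1 to the core of compound 3: the same change on two cores in this assay, a 4.4-fold higher number (0.64 log units; beyond the scatter) from compound 1 to compound 2 and a 1.5-fold higher number (0.18 log units; within the scatter) from compound 3 to compound 4, 2.9-fold (0.46 log units) apart, beyond the scatter of two such steps

The chain change likewise depends on the acyl group, giving a 2.6-fold lower number from compound 2 to compound 4 (0.42 log units; beyond the scatter) with isoquinolin-1-yl in place, and its size does not carry over from one acyl group to the other: the same change on two cores in this assay, a 1.1-fold higher number (0.04 log units; within the scatter) from compound 1 to compound 3 and a 2.6-fold lower number (0.42 log units; beyond the scatter) from compound 2 to compound 4, 2.9-fold (0.46 log units) apart, beyond the scatter of two such steps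

Both gaps rest on the same four values and so count as a single observation, which shows that the two changes do not add up simply in this set but does not show why, or how either change would behave on any other core.

Open, on these data alone, is whether the step between the two acyl groups would differ again with a longer chain or a shorter chain. Also open, as far as these compounds go, is how an acyl group carrying an amine or a carboxylic acid would respond to the same chain change.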